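Branched side chain swap in a transmembrane protease inhibitor series

The source may report more compounds than this note shows. Statements on the series, on what has been measured and on what is new or still open speak of the compounds shown alone.

Compound 1 `N=C(N)c1ccc(CNC(=O)[C@@H]2CCCN2C(=O)[C@@H](CC(=O)N2CCOCC2)NS(=O)(=O)Cc2ccccc2)cc1` gives 183 nM in an assay on isolated protein for inhibition of transmembrane protease serine 11D (Homo sapiens), read by fluorescence; a lower number here means a stronger inhibitor, a higher number a weaker inhibitor.
Compound 2 `CCC[C@H](NCc1ccc(C(=N)N)cc1)C(=O)[C@@H](CCCNC(=N)N)NS(=O)(=O)Cc1ccccc1` gives 15 nM in this assay.
Compound 3 `CC[C@H](C)[C@H](NCc1ccc(C(=N)N)cc1)C(=O)[C@@H](CCCNC(=N)N)NS(=O)(=O)Cc1ccccc1` gives 23 nM in this assay.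

Of the three measured compounds, compound 3 sits alongside compound 2, the two within the usual scatter of each other, while compound 1 lies well apart from both with a number beyond the scatter of compound 3. Compound 2 and compound 3 share the same arrangement apart from a single change, and in this assay that change gave a 1.5-fold higher number from compound 2 to compound 3 (0.19 log units; within the scatter).

Compound 4 `CC(C)C[C@H](NCc1ccc(C(=N)N)cc1)C(=O)[C@@H](CCCNC(=N)N)NS(=O)(=O)Cc1ccccc1` differs from compound 3 in one place: isobutyl in place of sec-butyl on a saturated chain carbon bound to an amine nitrogen and a carbonyl carbon. Among the compounds with values here, the only measured step that bears on this is the one from compound 2 to compound 3, which added a methyl on a saturated chain carbon bound to two saturated chain carbons and stayed within the scatter. Rearranging the same four carbons of this side chain is therefore expected to move the number in this assay little, if at all, in either direction. The expected step is a 1.1-fold higher number from compound 3 to compound 4 (0.04 log units; within the scatter). Compound 4 is estimated at 25 nM, with a range from 10 nM to 60 nM.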

Compound 4, inhibition constant: 47 nM
Beside the measured number, compound 4's estimate is 1.9-fold (0.27 log units) below it; measured number inside the range.
By their numbers in this assay, from the lowest: compounds 2 and 3 (each within the scatter of the next); then compound 4; then compound 1.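

In this assay, the side chain on a saturated chain carbon bound to an amine nitrogen and a carbonyl carbon turns out not to be interchangeable among groups of the same atoms: the swap of sec-butyl for isobutyl gives a 2.0-fold higher number from compound 3 to compound 4 (0.31 log units; beyond the scatter), a modest step, though only just past the scatter. The methyl-for-hydrogen change on the propyl chain of compound 2 also now has two readings, since the earlier step stayed within the scatter, while the same kind of change, placed so that it gives the isobutyl group, gives a 3.1-fold higher number from compound 2 to compound 4 (0.50 log units; beyond the scatter); among these three compounds, then, what a methyl does depends on which chain carbon carries it, and the unbranched propyl chain and sec-butyl remain level within the scatter. Nothing shown here gives a measured reason for this difference.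

The compounds shown leave open how a straight butyl chain, or a side chain ending in a hydroxyl or an amine, would read at this carbon. They also leave open whether the defined stereocentre of the sec-butyl group bears on the number, as only one arrangement of it appears here.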